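The source may hold more compounds than are shown below. What is called first, only, known or untested is meant among the compounds shown, and "the series" means these compounds.

For the measured compounds named here, compound 1, `CCCC(CCC)Nc1ncnc2c1ncn2C1O[C@H](CO)[C@@H](O)[C@H]1O`, gives the only firm number here: in an assay on cell membranes for binding affinity to adenosine receptor A1 (Cavia porcellus), read by radioligand binding (on this read-out higher numbers stand for weaker inhibition and lower numbers for stronger inhibition), compound 1 gives 3.3 nM. Compound 2, `CCCn1c(=O)c2nc(-c3nn[nH]n3)[nH]c2n(CCC)c1=O`, is built on a different core. In this assay compound 2 gives > 10000 nM, which is a limit of the assay rather than a number. Compound 2 thus sits at the position described by the limit of > 10000 nM in this assay, at which 1 of the 2 values shown sits, with no measured value of its own.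

Compound 3, `CCCn1c(=O)c2nc(-c3ccco3)[nH]c2n(CCC)c1=O`, has not yet been measured in this assay. Its difference from compound 2 is furan-2-yl in place of 2H-tetrazol-5-yl on an aromatic carbon. Going by the values given here, no measured pair of neighbouring compounds shows how this kind of change moves binding, so any expectation rests on compound 2 alone. Compound 3 is nonetheless expected to bind well beyond the scatter more tightly than the limit recorded for compound 2, a step from compound 2 to compound 3 estimated at an at least 200-fold lower number from compound 2 to compound 3 (2.30 log units; beyond the scatter). Compound 3 is therefore estimated to give 50 nM in this assay, in a range from 8 nM to 400 nM.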

Compound 3, inhibition constant: 560 nM
For compound 3 the middle estimate is 11-fold (1.05 log units) below the measured one, and the stated range ends below it.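

The change from 2H-tetrazol-5-yl to furan-2-yl, on an aromatic carbon of the five-membered ring, gives in this assay an at least 17-fold lower number from compound 2 to compound 3 (1.25 log units; beyond the scatter). For the compounds shown here, this is the first sign that the group at this place has a large say in binding on this core, as compound 3 gives a firm number where its neighbour does not. Going by these compounds, that step is only a minimum, and its true size stays unknown, because compound 2 has a limit of the assay rather than a number: the limit of > 10000 nM in this assay, at which 1 of the 3 values shown sits.

The two groups differ at once in their ring hetero atoms and in their hydrogen-bond donors and acceptors, so this single exchange cannot show which difference matters. A phenyl ring or a carboxylic acid at the same place would help to separate them.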